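Homologation of a carboxyalkyl group on a shared core

The source may hold more compounds than are shown below. What is called first, only, known or untested is meant among the compounds shown, and "the series" means these compounds.

Compound 1 `C[C@@H](C(=O)O)c1nn(Cc2cn3cc(OCC4CC4)c(Cl)cc3n2)c2ccccc2c1=O` gives 253 nM in a functional assay on CHO cells for antagonist activity at sphingosine 1-phosphate receptor 2 (Homo sapiens), read by GTPgammaS binding; on this read-out higher numbers stand for weaker inhibition and lower numbers for stronger inhibition. Compound 2 `COc1cc(OC)c(NC(=O)Cc2cn(CC(=O)O)c3ccccc23)cc1Cl` gives 17700 nM in this assay.

Of these two numbers, compound 1 stands lowest; compound 2 gives the higher number, and the gap lies beyond the scatter. Compound 3 `CCC(C(=O)O)c1nn(Cc2cn3cc(OCC4CC4)c(Cl)cc3n2)c2ccccc2c1=O` differs from compound 1 in one place: 1-carboxypropyl in place of 1-carboxyethyl on an aromatic carbon. For the measured compounds named here, no step between measured compounds bears on this change. With only compound 1 at 253 nM to go on, the step is expected to stay within the scatter a 1.2-fold higher number from compound 1 to compound 3 (0.07 log units; within the scatter). Compound 3 is estimated at 300 nM, with a range from 100 nM to 1000 nM.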

Compound 3, half-maximal inhibitory concentration: 43 nM
The estimate for compound 3 lay 7.0-fold (0.84 log units) above the measured number; measured number below the stated range.
By their numbers in this assay, from the lowest: compound 3; then compound 1; then compound 2.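

In this assay, 1-carboxypropyl in place of 1-carboxyethyl gives a 5.9-fold lower number from compound 1 to compound 3 (0.77 log units; beyond the scatter), so this position on the shared core responds to a small extension of the chain. The entering group has no defined stereocentre whereas the leaving group has one, so the effects of chain length and stereochemistry cannot be separated here. Nothing available accounts for the step.

As far as these compounds go, it remains open whether a longer chain such as 1-carboxybutyl would extend the trend. Also open, from the compounds shown here alone, is how each single stereoisomer of compound 3 would compare, and whether an amide could stand in for the carboxylic acid.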